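Hydroxypyrrolidine sulfonamide replacing an alkyl sulfone

The source may report more compounds than this note shows. Statements on the series, on what has been measured and on what is new or still open speak of the compounds shown alone.

Measured so far in a functional assay on MIA PaCa-2 cells (Homo sapiens) for inhibition, read by MTT assay, with a stated time of 7 days; on this read-out lower numbers stand for stronger inhibition and higher numbers for weaker inhibition:
- compound 1 `CCC(CC)S(=O)(=O)c1ccc(S(=O)(=O)N2CCC[C@@H](C(=O)N3CCC(F)(F)CC3)C2)cc1` gives 13 nM
- compound 2 `CCN(CC)S(=O)(=O)c1ccc(S(=O)(=O)N2CCC[C@@H](C(=O)N3CCC(COC)CC3)C2)cc1` gives 250 nM

Of the two compounds measured in this assay, compound 1 stands at the lower number, and the gap to compound 2 lies well beyond the scatter of the read-out, so compound 1 is the more potent of the pair. Compound 2 differs from compound 1 in more than one place, so the two values show only that the pairing of its groups gives a weaker result, and nothing is known about which part of that difference matters.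

Compound 3 `O=C([C@@H]1CCCN(S(=O)(=O)c2ccc(S(=O)(=O)N3CC[C@H](O)C3)cc2)C1)N1CCC(F)(F)CC1` is the next compound to be tested in this assay. It differs from compound 1 in one place: 3-hydroxypyrrolidin-1-yl in place of pentan-3-yl on a sulfonyl sulfur. Among the measured compounds shown here, no measured pair here isolates this kind of change. Given only the weaker value of compound 2 among the measured compounds, he expects a moderate loss from compound 1 to compound 3, a 4.6-fold higher number from compound 1 to compound 3 (0.66 log units; beyond the scatter), rather than a gain. Compound 3 is therefore estimated at 60 nM in this assay, with a likely range from 15 nM to 300 nM.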

Compound 3, half-maximal inhibitory concentration: 590 nM
For compound 3 the middle estimate is 9.8-fold (0.99 log units) below the measured one; measured number outside the range, above it.
By their numbers in this assay, from the lowest: compound 1; then compound 2; then compound 3.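

In this assay, among the compounds shown here, replacing pentan-3-yl with 3-hydroxypyrrolidin-1-yl on a sulfonyl sulfur whose other neighbour is an aromatic carbon gives a 45-fold higher number from compound 1 to compound 3 (1.66 log units; beyond the scatter), the first reading here of a single change at this place. Because the rest of compound 1 is kept, the large step belongs to this exchange alone, which the earlier pair could not show, and it shows that this place is far from indifferent to what sits on the sulfonyl sulfur. Nothing available here accounts for the size of this loss.

The exchange alters several things at once: an open carbon chain with no hydrogen-bond donor or acceptor gives way to a five-membered ring that brings a nitrogen, a hydroxyl group and a defined stereocentre, and the compounds shown do not separate these features. Plain pyrrolidin-1-yl, cyclopentyl or the opposite stereoisomer of 3-hydroxypyrrolidin-1-yl on the same sulfur would each leave open a different part of the change, so whether the hydroxyl group, the ring nitrogen or the ring itself carries the loss remains unknown.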